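Propoxycarbonyl to benzyloxycarbonyl: compound 2 to compound 3

This account rests on a few compounds, and the source may have more. Where it says the series, first, only, none or still open, it means among the compounds named here.

In an ADME assay (liver) for pharmacokinetics, with Liver microsome (Homo sapiens) as the target, using microsomes (a lower number here means that the compound disappears faster, a higher number that the compound lasts longer), compound 1 `CCOc1cc(NC(=O)C2(NC(=O)c3ccc4c(C5CCCC5)c(-c5ncc(Cl)cn5)n(C)c4c3)CCC2)ccc1/C=C/C(=O)OCOP(=O)(O)OC(C)(C)C` gives 1.48 h as its half-life. Compound 2 `CCCOC(=O)/C=C/c1ccc(NC(=O)C2(NC(=O)c3ccc4c(C5CCCC5)c(-c5ncc(Cl)cn5)n(C)c4c3)CCC2)cc1OCC` stands at > 5 h and this is a limit, not a number. Compound 3 `CCOc1cc(NC(=O)C2(NC(=O)c3ccc4c(C5CCCC5)c(-c5ncc(Cl)cn5)n(C)c4c3)CCC2)ccc1/C=C/C(=O)OCc1ccccc1` has phenyl in place of ethyl on a saturated chain carbon bound to an oxygen next to a carbonyl group. Within the data shown here, one measured step bears on this place: an at least 3.3-fold higher number from compound 1 to compound 2 (0.52 log units; beyond the scatter) with the smaller group giving the higher number. The group grows again here, so a modest fall is expected, and an at least 1.4-fold lower number from compound 2 to compound 3 (0.15 log units; that floor lies within the scatter) is the estimated step. Compound 3 is estimated at 3.5 h with an expected range of 1.5 h to 8 h for its half-life.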

Compound 3, half-life: > 5 h
Compound 3: only a limit was reported; the forecaster's own chance of this, stated with the estimate: 40%; middle value at least 1.4-fold (0.15 log units) away from the limit.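

In this assay compound 3 gives > 5 h, which is a limit and not a number. Benzyl at this place gives an at least 3.3-fold higher number from compound 1 to compound 3 (0.52 log units; beyond the scatter), so the larger group with its six-membered aromatic ring does not bring the half-life back down, and the readable gain seen with propyl holds for benzyl too. The step between propyl and benzyl cannot be read: the limit of > 5 h in this assay, at which 2 of the 3 values shown sit.

As far as these compounds go, how far past the limit either group lies stays open. Also open, from the compounds shown here alone, is whether a methyl group or a carboxylic acid at this place would stay at that limit.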